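Ethyl in place of phenyl on the chain

A few compounds are considered here, and "the series" means these few. Any claim that something is new, unique, unknown or untested is made for them only; others in the source may bear on it.

In a physicochemical assay for metabolic stability, read by HPLC, at pH 4.5, tested at 10 uM (on this read-out higher numbers stand for a longer-lived compound and lower numbers for a shorter-lived compound), compound 1 `O=C(NCCCCc1ccccc1)n1nnc2ccccc21` gives > 2 h, which is a limit of the assay and not a number. Compound 2 `O=C(NCCCCc1ccccc1)n1nnc2ncccc21` gives > 2 h, which is also a limit. The measurements so far come down to the limit of > 2 h in this assay, at which 2 of the 2 values shown sit. Within the data shown here, compound 1 therefore has no exact place on this scale, and no measured step is available to set a size for the next one.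

Compound 3 `CCCCCCNC(=O)n1nnc2ccccc21` has not yet been measured. The change from compound 1 to compound 3 is ethyl in place of phenyl on a saturated chain carbon, four bonds along the chain from an amide-type nitrogen. The shared core stays as it is.

No step beyond the scatter is expected in this assay, in either direction. This expectation rests on compound 1, whose limit is > 2 h. The estimated step is a step that the limit leaves unreadable from compound 1 to compound 3, and it is expected to stay within the scatter. Compound 3 is expected at 3 h, with an estimated range from 2 h to 8 h. A reading that is only a limit is also expected to be likely.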

Compound 3, half-life: > 2 h
Compound 3: a limit, no number; the forecaster's own chance of this, stated with the estimate: 75%; the middle value lies beyond the limit too.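

Compound 1 and compound 3 cannot be separated in this assay: both readings are limits of the assay and not numbers, and no step can be read between them. The compounds shown leave open the actual half-life of each compound, and whether ethyl in place of phenyl on the chain shifts it at all.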